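Aryl thioether variation on a shared cinnamamide core

The compounds below may be only part of what the source reports. "The series", "measured", "known", "first", "only" and "open" are said of these compounds alone.

Measured compounds:
compound 1 `Nc1ccccc1NC(=O)/C=C/c1ccc(CSc2ccc(F)cc2)cc1` — 10.4%
compound 2 `CC(C)(C)c1ccc(SCc2ccc(/C=C/C(=O)Nc3ccccc3N)cc2)cc1` — 9.8%
compound 3 `Nc1ccccc1NC(=O)/C=C/c1ccc(CSc2ccc(C(F)(F)F)cn2)cc1` — 6.82%

In a functional assay on HeLa cells (Homo sapiens) for inhibition, read by CCK-8 assay, with a stated time of 72 h, tested at 8 uM (a higher number here means more inhibition of growth at the concentration tested, a lower number less inhibition of growth), compound 3 gives the lowest of the three numbers, yet its nearest neighbour compound 2 and the furthest, compound 1, both sit within the scatter of it. The step to compound 4 `CCc1ccc(SCc2ccc(/C=C/C(=O)Nc3ccccc3N)cc2)cc1` is 4-ethylphenyl in place of 5-(trifluoromethyl)pyridin-2-yl on a sulfur. Within the data shown here, the steps that bear on it are a number 3 percentage points lower from compound 2 to compound 3 (within the scatter) and a number 3.6 percentage points lower from compound 1 to compound 3 (within the scatter), both changes on the same sulfur, and a number 0.6 percentage points lower from compound 1 to compound 2 (within the scatter), a substituent swap on the aromatic carbon; none of them left the scatter. For compound 4 no step beyond the scatter is therefore expected in this assay, in either direction, and the step is estimated as a number 2.2 percentage points higher from compound 3 to compound 4 (within the scatter). Compound 4 is expected at 9%, between 2% and 16%.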

Compound 4, percent growth inhibition at one concentration: 20.9%
The estimate for compound 4 lay 11.9 percentage points below the measured number, outside the stated range (above it).
By their numbers in this assay, from the lowest: compounds 3, 2 and 1 (each within the scatter of the next); then compound 4.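

In this assay the group on the sulfur does matter, with a number 14.1 percentage points higher from compound 3 to compound 4 (beyond the scatter) when 4-ethylphenyl replaces 5-(trifluoromethyl)pyridin-2-yl. On the aromatic carbon, ethyl stands apart from both earlier substituents, with a number 11.1 percentage points higher from compound 2 to compound 4 (beyond the scatter) against tert-butyl and a number 10.5 percentage points higher from compound 1 to compound 4 (beyond the scatter) against fluoro, although compound 1 and compound 2 lie within the scatter of each other. No measurement available here accounts for this result.

As far as these compounds go, whether methyl, n-propyl or methoxy on the same aromatic carbon would match ethyl remains open. So does whether the step persists at other concentrations.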